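Thiazole Carboxamides on Prostate Cancer Cells: A Trimethoxy Variant

The compounds below may be only part of what the source reports. "The series", "measured", "known", "first", "only" and "open" are said of these compounds alone.

Compound 1 `O=C(NCc1ccccc1)c1csc(-c2c[nH]c3ccccc23)n1`: in a functional assay on PC-3 cells (Homo sapiens) for cytotoxicity, read by MTT assay, with a stated time of 48 h, in the absence of a further agent (a higher number here means a weaker inhibitor, a lower number a stronger inhibitor), compound 1 gives > 100000 nM, which is a limit of the assay rather than a number.
Compound 2 `COc1ccc(NC(=O)c2csc(-c3cn(Cc4ccc(Cl)cc4)c4ccccc34)n2)cc1`: in this assay compound 2 gives > 100000 nM, again a limit of the assay.
Compound 3 `COc1ccc(NC(=O)c2csc(-c3c[nH]c4ccc(F)cc34)n2)cc1`: in this assay compound 3 gives > 100000 nM, also a limit of the assay.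

Compound 2 therefore stands nowhere in particular among the numbers shown: every measured compound sits at the limit of > 100000 nM in this assay, at which 3 of the 3 values shown sit, and no compound is separated from another by more than the usual scatter. Among the compounds with values here, no pair of measured compounds differs in a single place, so no measured step is available to lean on.

Compound 4 `COc1cc(NC(=O)c2csc(-c3cn(Cc4ccc(Cl)cc4)c4ccccc34)n2)cc(OC)c1OC` has not yet been measured. It differs from compound 2 by 3,4,5-trimethoxyphenyl in place of 4-methoxyphenyl on an amide-type nitrogen.

With every measured value at the limit, the expectation for the step from compound 2 to compound 4 in this assay is none beyond the scatter, and most likely a second limit; the estimated step is a number no higher from compound 2 to compound 4 (the limit leaves the size open). For compound 4 the estimate in this assay is 100000 nM, with a range from 20000 nM to 300000 nM.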

Compound 4, half-maximal inhibitory concentration: > 100000 nM
Compound 4 ended at the assay's limit (the forecaster's own chance of this, stated with the estimate: 70%); the middle value lies on the limit itself.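

Compound 2 and compound 4 both stand at a limit of this assay, so the step between them, 3,4,5-trimethoxyphenyl in place of 4-methoxyphenyl on an amide-type nitrogen, cannot be read. The compounds shown leave open what actual number any of them would give, and whether any change yields one: the limit of > 100000 nM in this assay, at which 4 of the 4 values shown sit.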